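Moving a Methyl Group Around a Piperidine Ring

A few compounds are considered here, and "the series" means these few. Any claim that something is new, unique, unknown or untested is made for them only; others in the source may bear on it.

Three compounds share one core and were compared in a functional assay on MGC-803 cells (Homo sapiens) for antiproliferative activity, read by CCK-8 assay, with a stated time of 72 h, tested at 8 uM; a higher number here means a stronger effect of the compound at the concentration tested, a lower number a weaker effect. Compound 1, with the structure `Nc1ccccc1NC(=O)c1ccc(CSC(=S)N2CCN(C3CCCCC3)CC2)cc1`, gives 75.3%. Compound 2, with the structure `Nc1ccccc1NC(=O)c1ccc(CSC(=S)N2CCc3cc([N+](=O)[O-])ccc32)cc1`, gives 33.2%. Compound 3, with the structure `CC1CCCCN1C(=S)SCc1ccc(C(=O)Nc2ccccc2N)cc1`, gives 86.9%, the highest of the three numbers, a step above compound 1 that is beyond the scatter and a far larger one above compound 2.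

Compound 4, with the structure `CC1CCN(C(=S)SCc2ccc(C(=O)Nc3ccccc3N)cc2)CC1`, has not yet been measured. It differs from compound 3 in a single spot: 4-methylpiperidin-1-yl in place of 2-methylpiperidin-1-yl on a thiocarbonyl carbon. The two molecules hold the same atoms, joined differently. Going by the values given here, no measured pair shows what such a relocation of a methyl group does here, so the size of the step must be guessed from the neighbours alone.

The expectation for compound 4 is a number close to compound 3, with a step of a number 6.9 percentage points lower from compound 3 to compound 4 (within the scatter) that stays within the scatter or dips only slightly below it. The estimate for compound 4 in this assay is 80%, with a range from 62% to 92%.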

Compound 4, a percentage reported as inhibition, at one concentration (the size of the read-out at that concentration, not a potency): 81.9%
Compound 4: the middle estimate sits 1.9 percentage points below what was measured; the range from low to high includes it.
By their numbers in this assay, from the lowest: compound 2; then compounds 1, 4 and 3 (each within the scatter of the next, the first and the last beyond it).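

In this assay, going by these compounds alone, the swap of 2-methylpiperidin-1-yl for 4-methylpiperidin-1-yl on a thiocarbonyl carbon gives a number 5 percentage points lower from compound 3 to compound 4 (within the scatter) and is the first comparison in this set where only one place changes. It shows that this relocation of the methyl group, which leaves the atoms the same and only joins them differently, produces no difference that can be told from ordinary scatter at the single concentration tested, so this ring accepts the methyl group in either of these two places. Nothing available here explains why the two compounds read alike.

Going by these compounds, whether a piperidine ring with no methyl group, an ethyl group in place of the methyl, or a morpholine ring would read the same remains open. The read-out also gives the size of the effect at one concentration rather than a potency, so compound 3 and compound 4 could still separate at other concentrations.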